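A few compounds are considered here, and "the series" means these few. Any claim that something is new, unique, unknown or untested is made for them only; others in the source may bear on it.

Compound 1, `C[n+]1ccn(COCCCCS(C)(=O)=O)c1/C=N/O`, gives -3.11 in a physicochemical assay for lipophilicity; a lower number here means a more polar compound, a higher number a more lipophilic compound. Compound 2, `CN(C)CCCn1cc[n+](C)c1/C=N/O`, gives in this assay only a limit of the assay, < -3. Compound 3, `C[n+]1ccn(CCNS(=O)(=O)C(F)(F)F)c1/C=N/O`, gives -1.2 in this assay.

Among the two real numbers, compound 3 stands highest; the nearest number, that of compound 1, sits well under it, a gap beyond the usual scatter. Compound 2 sits at the limit, as the limit of < -3 in this assay, at which 1 of the 3 values shown sits, records.

Compound 4, `C[n+]1ccn(CCN(Cc2ccccc2)S(=O)(=O)C(F)(F)F)c1/C=N/O`, has not yet been measured. It differs from compound 3 in one place: benzyl in place of hydrogen on a sulfonamide nitrogen. Among the compounds with values here, no measured pair shows a change of this kind, so its size cannot be read from the data. Even so, an upward step in this assay is expected, larger than the scatter. For compound 4 the expected value is 0.5, with a range from -0.3 to 1.3. The expected step is a number 1.70 log units higher from compound 3 to compound 4 (beyond the scatter).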

Compound 4, distribution coefficient: -0.01
Beside the measured number, compound 4's estimate is 0.51 log units above it; the measured number falls inside the stated range.
By their numbers in this assay, from the lowest: compound 1; then compound 3; then compound 4.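

Benzyl in place of hydrogen on a sulfonamide nitrogen gives, in this assay, a number 1.19 log units higher from compound 3 to compound 4 (beyond the scatter). This is the first change in a single place that can be read among these compounds, and it shows that this position can move the read-out well past the usual scatter. Nothing measured here says why the step has this size.

This is one change at one position. On these data alone, whether methyl, or a benzyl carrying an amine or a carboxylic acid, would move the number in the same way stays open.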